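The source may hold more compounds than are shown below. What is called first, only, known or untested is meant among the compounds shown, and "the series" means these compounds.

Measured in a functional assay on KG-1a cells (Homo sapiens) for inhibition, with a stated time of 24 h; on this read-out lower numbers stand for stronger inhibition and higher numbers for weaker inhibition:
- Compound 1 `O=[N+]([O-])c1ccccc1Nc1nnc(-c2c[nH]c3ccccc23)o1`: 850 nM
- Compound 2 `O=[N+]([O-])c1ccc(Nc2nnc(-c3c[nH]c4ccccc34)o2)cc1`: 890 nM

Compound 2, at 890 nM, stands within the usual scatter of compound 1, at 850 nM, so these two numbers cannot be told apart. Compound 3 `Clc1ccc(Nc2nnc(-c3c[nH]c4ccccc34)o2)cc1` keeps the core of compound 2 and differs from it in one place: chloro in place of nitro on an aromatic carbon, para to a large group (chloro in place of nitro on an aromatic carbon). Within the data shown here, no measured pair yet shows what a single change of this kind does in this assay, so any forecast is uncertain. A small move toward a lower number is expected, and it may well stay within the scatter. The estimated step is a 1.4-fold lower number from compound 2 to compound 3 (0.14 log units; within the scatter). Compound 3 is expected to give about 650 nM, with an estimated range of 180 nM to 2300 nM.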

Compound 3, half-maximal inhibitory concentration: 3160 nM
Estimate against measurement, compound 3: 4.9-fold (0.69 log units) below, and the stated range ends below it.
By their numbers in this assay, from the lowest: compounds 1 and 2 (each within the scatter of the next); then compound 3.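

In this assay the change from nitro to chloro on an aromatic carbon, para to a large group, moves the number upward (a 3.6-fold higher number from compound 2 to compound 3 (0.55 log units; beyond the scatter)), and this step lies beyond the scatter. Among these compounds, this is the first single-change pair, and it shows that the group at this position affects the read-out, which compounds 1 and 2 could not show alone. Nitro brings hydrogen-bond acceptors and chloro brings none, but no measurement at hand says whether that difference or another one lies behind the step.

As far as these compounds go, it remains open whether an amine or a methoxy group at this position would give a number closer to that of compound 2 or that of compound 3. Also open, from the compounds shown here alone, is whether the same swap on compound 1 would shift the number in the same direction.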